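Same atoms, joined differently: compound 2 to compound 4

A few compounds are considered here, and "the series" means these few. Any claim that something is new, unique, unknown or untested is made for them only; others in the source may bear on it.

Values in a functional assay on HepG2 cells (Homo sapiens) for antiproliferative activity, read by MTT assay, with a stated time of 72 h; a lower number here means a stronger inhibitor, a higher number a weaker inhibitor:
- compound 1 `O=C1O/C(=C\Cn2cnc3c(F)nc(F)c(Cl)c32)C(OCc2ccccc2)=C1OCc1ccccc1`: > 100000 nM
- compound 2 `O=C1O/C(=C\Cn2cnc3cncc(Br)c32)C(OCc2ccccc2)=C1OCc1ccccc1`: 46900 nM
- compound 3 `O=C1NC(O)(CCn2cnc3ccn(CCC4(O)NC(=O)C(OCc5ccccc5)=C4OCc4ccccc4)c3c2=O)C(OCc2ccccc2)=C1OCc1ccccc1`: > 100000 nM; 52000 nM (2 entries)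

The value of compound 1 is a limit. One of the two entries of compound 3 is also a limit. Going by the values given here, that leaves compound 2 as the only compound with a single number, 46900 nM.

Compound 4 `O=C1O/C(=C\Cn2cnc3ncc(Br)c-3c2)C(OCc2ccccc2)=C1OCc1ccccc1` has the same atoms as compound 2, joined differently, on a saturated chain carbon bound to a double-bonded chain carbon: a group of 10 heavy atoms (6 carbon, 3 nitrogen, 1 bromine; one five-membered aromatic ring with 1 hetero atom, one six-membered aromatic ring with 2 hetero atoms) in place of a group of 10 heavy atoms (6 carbon, 3 nitrogen, 1 bromine; one five-membered aromatic ring with 2 hetero atoms, one six-membered aromatic ring with 1 hetero atom), on a saturated chain carbon bound to a double-bonded chain carbon.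

One measured step changes this same place: an at least 2.1-fold lower number from compound 1 to compound 2 (0.32 log units; beyond the scatter). It starts from a limit and involves a different change, so it gives no measure of a rearrangement of this kind. Among the compounds with values here, compound 3 offers no single-place step.

With compound 2 at 46900 nM as the only anchor, no step beyond the scatter is expected in this assay, in either direction: a 1.1-fold higher number from compound 2 to compound 4 (0.03 log units; within the scatter). The estimate for compound 4 is 50000 nM, with an expected range of 20000 nM to 100000 nM.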

Compound 4, half-maximal inhibitory concentration: > 100000 nM
Compound 4 was reported as a limit; the forecaster's own chance of this, stated with the estimate: 30%; at least 2.0-fold (0.30 log units) between middle value and limit.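

In this assay, the place on a saturated chain carbon bound to a double-bonded chain carbon responds to the arrangement of the group as well as to its composition: swapping the group with one five-membered aromatic ring with 2 hetero atoms and one six-membered aromatic ring with 1 hetero atom for the one with one five-membered aromatic ring with 1 hetero atom and one six-membered aromatic ring with 2 hetero atoms gives an at least 2.1-fold higher number from compound 2 to compound 4 (0.32 log units; beyond the scatter) as its step. Atom, donor and acceptor counts are identical in the two groups, which the earlier step from a different substituent pattern could not isolate. Compound 4 gives > 100000 nM which is a limit, so the step has only a minimum size, and the step from compound 1 to compound 4 cannot be read.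

Much of the series offers no exact number for comparison: the limit of > 100000 nM in this assay, at which 2 of the 4 values shown sit. Going by these compounds, whether a longer chain carrying an amine at this place would bring the number under that limit remains open.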